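Swapping an Aryl Ether for an Alkyl Chain

The compounds below may be only part of what the source reports. "The series", "measured", "known", "first", "only" and "open" are said of these compounds alone.

Measured compounds:
compound 1 `COc1ccc(Oc2ccc3c(NCCCNCc4cc(F)ccc4OC)ccnc3c2)cc1`: 9.28
compound 2 `c1ccc(Oc2ccc3c(NCCCNCc4ccco4)ccnc3c2)cc1`: 9.28
compound 3 `c1ccc(-c2ccc3c(NCCCNCc4ccco4)ccnc3c2)cc1`: 9.47

In a physicochemical assay for acid dissociation, compound 1 gives 9.28, level with compound 2 at the digits shown, and these two are together the lowest of the three numbers. Within the data shown here, the single step between measured compounds is a number 0.19 log units higher from compound 2 to compound 3 (within the scatter), so compound 3 stands within the scatter of compound 1 as well.

Compound 4 `COc1ccc(F)cc1CNCCCNc1ccnc2cc(CCC(C)C)ccc12` has not been measured. It differs from compound 1 in one place: isopentyl in place of 4-methoxyphenoxy on an aromatic carbon. Among the measured compounds shown here, the one step that bears on this, a number 0.19 log units higher from compound 2 to compound 3 (within the scatter), also exchanges a group on an aromatic carbon of the shared core and stayed within the scatter. A step of no size beyond the scatter is therefore expected, a number 0.07 log units higher from compound 1 to compound 4 (within the scatter). Compound 4 is estimated to give 9.35, in the range 9 to 9.7.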

Compound 4, acid dissociation constant: 9.47
The estimate for compound 4 lay 0.12 log units below the measured number; the range from low to high includes it.
By their numbers in this assay, from the lowest: compounds 1, 2, 3 and 4 (each within the scatter of the next).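

In this assay the step on this position is a number 0.19 log units higher from compound 1 to compound 4 (within the scatter) and so stays within the scatter. The earlier step kept a ring in the entering group, whereas isopentyl has no ring and no hydrogen-bond acceptors, so this position tolerates a ring-free alkyl chain in place of 4-methoxyphenoxy without a shift beyond the scatter. No measurement shown gives a reason for this result.

From the compounds shown here alone, whether an amine or a carboxylic acid at this position would also stay within the scatter remains open. So does the effect of a longer chain.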